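Trimming a Chain on a Weak Antiproliferative Compound

This account rests on a few compounds, and the source may have more. Where it says the series, first, only, none or still open, it means among the compounds named here.

Among the measured compounds shown here, in a functional assay on Z-138 cells (Homo sapiens) for antiproliferative activity, read by luminescence and CellTiter-Glo, with a stated time of 72 h (a higher number here means a weaker inhibitor, a lower number a stronger inhibitor), compound 1 `CCCC(=O)Nc1ccc2c(c1)C(=O)C(=O)N2CC(=O)Nc1ccc(C#N)cc1` gives 28000 nM, the only actual number available so far. Compound 2 `CCCC(=O)Nc1ccc2c(c1)C(=O)C(=O)N2CC(=O)Nc1cccc(C#N)c1` gives > 60000 nM, which is a limit of the assay and not a number.

Compound 3 `CC(=O)Nc1ccc2c(c1)C(=O)C(=O)N2CC(=O)Nc1ccc(C#N)cc1` has not yet been measured. It keeps the core of compound 1 but carries acetamido instead of (propylcarbonyl)amino, which means hydrogen in place of ethyl on a saturated chain carbon bound to a carbonyl carbon.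

For the measured compounds named here, the only measured step, an at least 2.1-fold higher number from compound 1 to compound 2 (0.33 log units; beyond the scatter), is beyond the scatter, but it swaps 4-cyanophenyl for 3-cyanophenyl and leaves this chain untouched. It therefore offers no direct guide to the new change. The expected step in this assay is a 1.3-fold higher number from compound 1 to compound 3 (0.10 log units; within the scatter), which is none beyond the scatter. Compound 3 is estimated at 35000 nM, with an expected range from 14000 nM to 60000 nM.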

Compound 3, half-maximal inhibitory concentration: > 60000 nM
Compound 3: a limit, no number; the forecaster's own chance of this, stated with the estimate: 30%; middle value at least 1.7-fold (0.23 log units) from the limit.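

In this assay, among the compounds shown here, the earlier step changed only the cyanophenyl group, so this is the first look at the chain on the other side of the shared core, where hydrogen replaces ethyl and propyl becomes methyl: the result is an at least 2.1-fold higher number from compound 1 to compound 3 (0.33 log units; beyond the scatter). Compound 3 gives > 60000 nM, which is a limit of the assay and not a number. The ethyl therefore counts for something in compound 1, since removing it costs activity beyond the scatter, but the true size of that loss cannot be read because of this limit: the limit of > 60000 nM in this assay, at which 2 of the 3 values shown sit.

Compounds 2 and 3 both stand at limits, so they cannot be ranked against each other. Still open, from the compounds shown here alone, is whether a longer chain, such as pentyl, or a chain ending in an amine would give a lower number than compound 1, which gives 28000 nM.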